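Indolylethyl to phenethyl swap on the triazole side chain

The compounds below may be only part of what the source reports. "The series", "measured", "known", "first", "only" and "open" are said of these compounds alone.

Measured compounds in an in vitro assay on LLC-PK1 cells for displacement of a labelled ligand from growth hormone secretagogue receptor type 1 (Homo sapiens); on this read-out higher numbers stand for weaker inhibition and lower numbers for stronger inhibition:
compound 1, `COc1ccc(Cn2c(CCc3c[nH]c4ccccc34)nnc2[C@H](NC(=O)C(C)(C)N)c2c[nH]c3ccccc23)c(OC)c1`, 108 nM
compound 2, `COc1ccc(Cn2c(CCc3ccccc3)nnc2[C@H](NC(=O)C(C)(C)N)c2c[nH]c3ccccc23)c(OC)c1`, 60 nM
compound 3, `COc1ccc(Cn2c(CCc3c[nH]c4ccccc34)nnc2[C@H](NC(=O)c2ccccn2)c2c[nH]c3ccccc23)cc1`, 1.9 nM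

Compound 3 carries the lowest number of the three in this assay. The core of compound 3 and the core of compound 1 differ in more than one place; the difference between the two cores is not broken down here.

Compound 2 differs from compound 1 by phenyl in place of 1H-indol-3-yl on a saturated chain carbon, two bonds along the chain from an aromatic carbon, and this gives a 1.8-fold lower number from compound 1 to compound 2 (0.26 log units; within the scatter).

Compound 4, `COc1ccc(Cn2c(CCc3ccccc3)nnc2[C@H](NC(=O)c2ccccn2)c2c[nH]c3ccccc23)cc1`, is not yet measured. It differs from compound 3 by phenyl in place of 1H-indol-3-yl on a saturated chain carbon, two bonds along the chain from an aromatic carbon; the place is the same as between compound 1 and compound 2, so this is the same change made on a different core.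

Within the data shown here, compound 1 and compound 2 are the only pair showing this change, so the expectation rests on one step. Starting from compound 3, the change is expected to give a 1.5-fold lower number from compound 3 to compound 4 (0.16 log units; within the scatter), set beside the measured 1.8-fold lower number from compound 1 to compound 2 (0.26 log units; within the scatter) and kept within the scatter. Compound 4 is therefore estimated at 1.3 nM in this assay, with a range from 0.5 nM to 4 nM.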

Compound 4, half-maximal inhibitory concentration: 0.7 nM
Estimate against measurement, compound 4: 1.9-fold (0.27 log units) above, within the range that was stated.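

In this assay, phenyl in place of 1H-indol-3-yl gives a 2.7-fold lower number from compound 3 to compound 4 (0.43 log units; beyond the scatter), in the same direction as a 1.8-fold lower number from compound 1 to compound 2 (0.26 log units; within the scatter). The two steps do not differ, so on these two cores the change carries over with no measurable dependence on the core: the same change on two cores in this assay, a 1.8-fold lower number (0.26 log units; within the scatter) from compound 1 to compound 2 and a 2.7-fold lower number (0.43 log units; beyond the scatter) from compound 3 to compound 4, 1.5-fold (0.18 log units) apart, within the scatter of two such steps. Among these compounds, this does not show that the change would carry to any further core, since only one pair stands on each core, and the cores of compound 1 and compound 3 differ in more than one place, which leaves no single core feature tied to the size of either step.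

Open, going by these compounds, is whether the same holds when the phenyl ring carries a substituent such as fluorine, an amine or a carboxylic acid. Also open, on these data alone, is whether a longer chain such as 3-phenylpropyl, or a saturated ring such as cyclohexyl, would behave like phenethyl on either core.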